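Working notes: methyl for chloro, compound 2 to compound 4

The source may hold more compounds than are shown below. What is called first, only, known or untested is meant among the compounds shown, and "the series" means these compounds.

Measured in a functional assay on MDA-MB-435S cells (Homo sapiens) for cytotoxicity, read by MTT assay, with a stated time of 72 h; a higher number here means a weaker inhibitor, a lower number a stronger inhibitor:
- compound 1 `Cc1cc(C)n2nc(SCc3nnc(SCc4coc5ccccc5c4=O)n3-c3ccccc3)nc2n1` gives 2900 nM.
- compound 2 `Cc1nnc(SCc2cc(=O)c3cc(Cl)ccc3o2)o1` returns only the limit > 25000 nM.
- compound 3 `Nc1nnc(SCc2cc(=O)c3cc(Cl)ccc3o2)s1` returns only the limit > 25000 nM.

Compound 2 stands at the limit of this assay, not at a number. Compound 3 is at that limit as well, so two of the three values shown sit there (the limit of > 25000 nM in this assay, at which 2 of the 3 values shown sit), and only compound 1 yields a readable number in this assay. Within the data shown here, the one measured step on the shared core of compound 2, a step that the two limits leave unreadable from compound 2 to compound 3, is therefore unreadable in size and direction.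

Compound 4 `Cc1ccc2oc(CSc3nnc(C)o3)cc(=O)c2c1` differs from compound 2 only by methyl in place of chloro on an aromatic carbon. Among the measured compounds shown here, no measured step bears on this exchange in a readable way: the step to compound 3 is unreadable, and compound 1 belongs to a different core. With compound 2 at the limit, the expectation for compound 4 is a step that the limit leaves unreadable from compound 2 to compound 4, meaning no movement that can be read, and most probably another limit. The estimate for compound 4 in this assay is 35000 nM, within 8000 nM to 150000 nM.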

Compound 4, half-maximal inhibitory concentration: > 25000 nM
Compound 4 gave a limit, no number (the forecaster's own chance of this, stated with the estimate: 75%); the middle value is on the limit's open side.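

No step can be read from compound 2 to compound 4, as each returns only a limit: the limit of > 25000 nM in this assay, at which 3 of the 4 values shown sit.

The compounds shown leave open whether methyl in place of chloro on an aromatic carbon changes the activity of the shared core at all.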